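Swapping a Halogen in a Weakly Active Series

This account rests on a few compounds, and the source may have more. Where it says the series, first, only, none or still open, it means among the compounds named here.

Compound 1 `COc1ccc(C(=O)/C=C/c2ccc(Br)cc2)c2c1C=CC(C)(C)O2` was examined in a functional assay on K562 cells (Homo sapiens) for antiproliferative activity, read by MTT assay, with a stated time of 24 h; a higher number here means a weaker inhibitor, a lower number a stronger inhibitor. In this assay compound 1 gives > 10000 nM, which is a limit of the assay rather than a number. Two further compounds carry the same core with a different group on the outer aromatic ring. Compound 2 `COc1ccc(C(=O)/C=C/c2ccc(-n3ccnc3)cc2)c2c1C=CC(C)(C)O2` gives > 10000 nM in this assay, again a limit. Compound 3 `COc1ccc(C(=O)/C=C/c2ccc(C(F)(F)F)cc2)c2c1C=CC(C)(C)O2` gives > 10000 nM in this assay, also a limit. Going by the values given here, the steps a step that the two limits leave unreadable from compound 1 to compound 2, a step that the two limits leave unreadable from compound 1 to compound 3 and a step that the two limits leave unreadable from compound 2 to compound 3 therefore cannot be sized in either direction; the only firm evidence is the limit of > 10000 nM in this assay, at which 3 of the 3 values shown sit.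

Compound 4 `COc1ccc(C(=O)/C=C/c2cccc(Cl)c2)c2c1C=CC(C)(C)O2` has not yet been measured. It differs from compound 1 in one place: 3-chlorophenyl in place of 4-bromophenyl on a double-bonded chain carbon bound to a double-bonded chain carbon. Among the compounds with values here, no measured step follows this exact exchange, and the three measured steps give no readable size at all, so no step beyond the scatter can be predicted in either direction. Since every measured compound sits at the limit, compound 4 is expected to sit there as well, with an estimated value of 15000 nM and a range from 5000 nM to 50000 nM. The step this estimate implies, a step that the limit leaves unreadable from compound 1 to compound 4, is expected to be small.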

Compound 4, half-maximal inhibitory concentration: > 10000 nM
Compound 4 was reported as a limit; the forecaster's own chance of this, stated with the estimate: 85%; the middle value is on the limit's open side.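

In this assay compound 4 gives > 10000 nM, again a limit and not a number, so the exchange between compound 1 and compound 4 has no readable size. The firm evidence remains: the limit of > 10000 nM in this assay, at which 4 of the 4 values shown sit.

The compounds shown leave open how active each one truly is, and whether changing the outer aromatic ring alters activity in this assay.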